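A few compounds are considered here, and "the series" means these few. Any claim that something is new, unique, unknown or untested is made for them only; others in the source may bear on it.

Compounds measured in this study:
compound 1, `CCCc1cc(C(C)=O)c(O)cc1OCCCCC#N` — 84%
compound 2, `CCCCc1cc(C(C)=O)c(O)cc1OCCCCC#N` — 41%
compound 3, `CCCc1cc(C(C)=O)c(O)cc1OCCCCCC(=O)O` — 73%

In an assay on isolated protein for inhibition of leukotriene B4 receptor 1 (Homo sapiens), tested at 10 uM (on this read-out higher numbers stand for more inhibition at the one concentration tested (going by the name of the read-out) and lower numbers for less inhibition), compound 1 gives 84%, the highest of the three numbers shown. Its nearest neighbour is compound 3, a number 11 percentage points lower from compound 1 to compound 3 (beyond the scatter); furthest away is compound 2, a number 43 percentage points lower from compound 1 to compound 2 (beyond the scatter). Both of those steps concern the saturated chains, one the propyl group, the other the chain carrying the cyano end, and neither touches the hydroxy on the ring.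

Compound 4, `CCCc1cc(C(C)=O)c(Cl)cc1OCCCCC#N`, is the next compound to be measured. It differs from compound 1 in one place: chloro in place of hydroxy on an aromatic carbon. Among the measured compounds shown here, no measured step bears on this change, since neither the step from compound 1 to compound 2 nor the step from compound 1 to compound 3 alters a ring substituent. The measured steps only show that single changes on this core can move this assay by a large margin, as from compound 1 to compound 2, or by a modest one, as from compound 1 to compound 3.

For the measured compounds named here, with no direct precedent, the direction of the step for compound 4 is uncertain, and a wide range is expected. Compound 4 is estimated at 45%, between 10% and 80%, which would be the expected step of a number 39 percentage points lower from compound 1 to compound 4 (beyond the scatter).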

Compound 4, a percentage reported as inhibition, at one concentration (the size of the read-out at that concentration, not a potency): 35%
Beside the measured number, compound 4's estimate is 10 percentage points above it; the range from low to high includes it.
By their numbers in this assay, from the lowest: compounds 4 and 2 (each within the scatter of the next); then compound 3; then compound 1.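

Chloro in place of hydroxy on the aromatic carbon ortho to an acetyl group gives a number 49 percentage points lower from compound 1 to compound 4 (beyond the scatter) in this assay, the first evidence that a ring substituent on this core, and not only the saturated chains, can move this read-out by a large margin. The step is also large in the same sense as the chain change that gives a number 43 percentage points lower from compound 1 to compound 2 (beyond the scatter), so this one ring position is at least as open to a large change as the chain position, while compound 4 still shows 35% at the one concentration tested. The swap takes away the hydrogen-bond donor and acceptor counted for hydroxy and brings in none with chloro, but nothing shown ties the lower number to those counts or to anything else about the change.

The compounds shown do not separate losing hydroxy from gaining chloro, a question that methoxy, an amine or fluoro at the same place would address. They also leave open whether the same swap gives a step of similar size on the carboxylic acid chain of compound 3 or the longer chain of compound 2.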